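The source may hold more compounds than are shown below. What is called first, only, known or untested is meant among the compounds shown, and "the series" means these compounds.

The measured compounds, all in a functional assay on PC-3 cells (Homo sapiens) for cytotoxicity, read by colorimetric assay and MTT assay; a lower number here means a stronger inhibitor, a higher number a weaker inhibitor:

compound 1 `COc1ccc(-c2cc3c(OC)cc(OC)cc3n(CC#N)c2=O)cc1` gives 10000 nM
compound 2 `COc1ccc(-c2cc3c(OC)cc(OC)cc3n(CC(=O)OCc3ccccc3)c2=O)cc1` gives 10000 nM
compound 3 `COc1ccc(-c2cc3c(OC)cc(OC)cc3n(CCC#N)c2=O)cc1` gives 10000 nM

The three share a core and differ only in the group carried on the chain at the aromatic nitrogen. From compound 1 to compound 2 the change is benzyloxycarbonyl in place of cyano on a saturated chain carbon bound to an aromatic nitrogen, and in this assay it made no change at the digits printed from compound 1 to compound 2 (within the scatter). The cores of compound 1 and compound 3 differ by cyanomethyl in place of cyano on a saturated chain carbon bound to an aromatic nitrogen, with no change at the digits printed from compound 1 to compound 3 (within the scatter). Between compound 2 and compound 3 the reading is no change at the digits printed from compound 2 to compound 3 (within the scatter). Going by the values given here, all three values therefore sit level with one another, and no compound among them can be called more or less active than the others.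

Compound 4 `COc1ccc(-c2cc3c(OC)cc(OC)cc3n(CCC(=O)OCc3ccccc3)c2=O)cc1` has not yet been measured in this assay. It differs from compound 3 by benzyloxycarbonyl in place of cyano on a saturated chain carbon, two bonds along the chain from an aromatic nitrogen. This is the same kind of change as that from compound 1 to compound 2, not the same one: there the place was on a saturated chain carbon bound to an aromatic nitrogen, here it is on a saturated chain carbon, two bonds along the chain from an aromatic nitrogen. The expected step in this assay is no change at the digits printed from compound 3 to compound 4 (within the scatter), resting on the earlier step of no change at the digits printed from compound 1 to compound 2 (within the scatter), which left the value where it was. Compound 4 is accordingly expected to give 10000 nM, estimated to lie between 5000 nM and 20000 nM.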

Compound 4, half-maximal inhibitory concentration: 10000 nM
Compound 4: middle estimate and measured number agree at the digits printed, within the range that was stated.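

In this assay the new reading gives no change at the digits printed from compound 3 to compound 4 (within the scatter) and also no change at the digits printed from compound 2 to compound 4 (within the scatter) and no change at the digits printed from compound 1 to compound 4 (within the scatter) when set against the other two compounds, so all four stand level. Benzyloxycarbonyl in place of cyano thus carried from one core to the other without any difference between the two steps: the same change on two cores in this assay, no change at the digits printed (within the scatter) from compound 1 to compound 2 and no change at the digits printed (within the scatter) from compound 3 to compound 4, 1.0-fold (0.00 log units) apart, within the scatter of two such steps

Going by these compounds alone, this agreement shows only that the change left the value where it was in both cases; it joins two steps that both stayed level, and one such pair makes no rule for the series. It does not show how the same change would behave on a core whose value differs from these.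

The compounds shown leave open whether any group on this chain at the aromatic nitrogen can move the value at all, since nitrile and benzyl ester ends alone are represented here, and an amine, a carboxylic acid or a longer chain would put that to the test. They also leave open whether replacing the methoxy groups on the shared core with, for example, hydroxy groups would shift the reading.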